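Replacing the group on the amide nitrogen of compound 3

The source may report more compounds than this note shows. Statements on the series, on what has been measured and on what is new or still open speak of the compounds shown alone.

In an ADME assay on MT4 cells (Homo sapiens) for cytotoxicity, read by MTT assay, with a stated time of 5 days (a higher number here means that more compound is tolerated, a lower number that less compound is tolerated), compound 3 `Cc1cc(C)cc(S(=O)(=O)c2c(C(=O)NC3CN(Cc4ccccc4F)C3)[nH]c3ccc(Cl)cc23)c1` gives > 238000 nM, which is a limit of the assay and not a number. It therefore stands at the limit of > 238000 nM in this assay, at which 1 of the 3 values shown sits. Compound 1 `Cc1cc(C)cc(S(=O)(=O)c2c(C(=O)N[C@@H]3CCN(S(C)(=O)=O)C3)[nH]c3ccc(Cl)cc23)c1` gives 24000 nM, and compound 2 `Cc1cc(C)cc(S(=O)(=O)c2c(C(=O)N[C@@H]3CCN(CC(N)=O)C3)[nH]c3ccc(Cl)cc23)c1` gives 31000 nM. Compound 4 `CCCS(=O)(=O)NC(=O)c1[nH]c2ccc(Cl)cc2c1S(=O)(=O)c1cc(C)cc(C)c1` carries propylsulfonyl in place of 1-(2-fluorobenzyl)azetidin-3-yl on an amide-type nitrogen. Among the measured compounds shown here, two measured steps bear on losing that group, both beyond the scatter: an at least 9.9-fold higher number from compound 1 to compound 3 (0.99 log units; beyond the scatter) and an at least 7.6-fold higher number from compound 2 to compound 3 (0.88 log units; beyond the scatter). By contrast, a 1.3-fold higher number from compound 1 to compound 2 (0.11 log units; within the scatter) stays within the scatter. A step of similar size in the opposite direction is therefore expected, and the estimated step is an at least 5.9-fold lower number from compound 3 to compound 4 (0.77 log units; beyond the scatter). For compound 4 the estimate is 40000 nM, with an expected range of 10000 nM to 150000 nM.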

Compound 4, half-maximal cytotoxic concentration: 146000 nM
For compound 4 the middle estimate is 3.7-fold (0.56 log units) below the measured one; the measured number falls inside the stated range.
By their numbers in this assay, from the lowest: compounds 1 and 2 (each within the scatter of the next); then compound 4. At a limit, above all of these: compound 3.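

In this assay, a group with no ring on the amide-type nitrogen can also lift the number: propylsulfonyl gives a 4.7-fold higher number from compound 2 to compound 4 (0.67 log units; beyond the scatter) and a 6.1-fold higher number from compound 1 to compound 4 (0.78 log units; beyond the scatter). The higher numbers are therefore not tied to 1-(2-fluorobenzyl)azetidin-3-yl alone. The remaining step, an at least 1.6-fold lower number from compound 3 to compound 4 (0.21 log units; that floor lies within the scatter), has a floor within the scatter, so it shows no clear loss on leaving that group.

Going by these compounds, the true gap between these two compounds stays open because compound 3 sits at a limit of the assay: the limit of > 238000 nM in this assay, at which 1 of the 4 values shown sits. Also open, on these data alone, is whether an amine, a carboxylic acid or a longer chain on this nitrogen would give similar numbers.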